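Capping a Hydroxy Group on an Inactive Series

A few compounds are considered here, and "the series" means these few. Any claim that something is new, unique, unknown or untested is made for them only; others in the source may bear on it.

Compound 1 `CC(=O)Oc1ccc2cc(-n3cc(-c4ccc(C)cc4)nn3)c(=O)oc2c1C`: in a functional assay on MCF7 cells (Homo sapiens) for antiproliferative activity (on this read-out higher numbers stand for weaker inhibition and lower numbers for stronger inhibition), compound 1 gives > 100000 nM, a limit of the assay.
Compound 2 `COc1ccc(-c2cn(-c3cc4ccc(O)c(C)c4oc3=O)nn2)cc1`: in this assay compound 2 gives > 100000 nM, a limit of the assay.

Both values are limits rather than numbers: neither compound slowed the growth of the cells within the tested range, and both sit at the limit of > 100000 nM in this assay, at which 2 of the 2 values shown sit. Compound 2 therefore stands at the same limit as compound 1, and no order between the two can be read.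

Compound 3 `COc1ccc(-c2cn(-c3cc4ccc(OC(C)=O)c(C)c4oc3=O)nn2)cc1` differs from compound 2 by acetyl in place of hydrogen on an oxygen on an aromatic ring. Among the measured compounds shown here, no measured pair of this kind exists here, so the size of this step in this assay cannot be taken from data. Compound 1 already carries the acetoxy group and gives > 100000 nM, a limit. That gives no sign that the acetyl cap brings inhibition within reach. The expected step from compound 2 to compound 3 in this assay is a number no higher from compound 2 to compound 3 (the limit leaves the size open), none beyond the scatter. Compound 3 is expected to give about 100000 nM in this assay, between 40000 nM and 300000 nM, most likely again reported only as a limit.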

Compound 3, half-maximal inhibitory concentration: > 100000 nM
Compound 3 ended at the assay's limit; the forecaster's own chance of this, stated with the estimate: 85%; the middle value lies on the limit itself.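

Among the compounds shown here, compound 1, compound 2 and compound 3 all stop at a limit of this assay, so no step between compound 3 and either of the other two can be read: the limit of > 100000 nM in this assay, at which 3 of the 3 values shown sit.

The compounds shown leave open whether hydroxy and acetoxy differ at all in this series, and which change, if any, would give a measurable value.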